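The compounds below may be only part of what the source reports. "The series", "measured", "known", "first", "only" and "open" are said of these compounds alone.

Of the compounds shown here, three from one series have been tested in a functional assay on PC-3 cells (Homo sapiens) for antiproliferative activity, read by MTT assay, tested at 1 uM; on this read-out higher numbers stand for a stronger effect at the one concentration tested and lower numbers for a weaker effect. Compound 1, with the structure `COc1cc(C(=O)N/N=C/c2ccc(F)c(F)c2)cc(OC)c1OC`, gives 35.1%. Compound 2, with the structure `COc1ccc(C2OC(c3cc(OC)c(OC)c(OC)c3)=NN2C(C)=O)c(OC)c1`, gives 69.5%. Compound 3, with the structure `COc1cc(C(=O)N/N=C/c2ccc(C(F)(F)F)cc2)cc(OC)c1OC`, gives 59.9%. On these three numbers compound 2 stands highest: its nearest neighbour is compound 3, whose number lies within the usual scatter of compound 2, so the two cannot be ranked against each other; its furthest neighbour is compound 1, whose number lies beyond the scatter, clearly lower than that of compound 2.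

The next compound, compound 4, has the structure `COc1cc(C2=NN(C(C)=O)C(c3ccc(Cl)c(Cl)c3)O2)cc(OC)c1OC` and has not yet been measured in this assay. It differs from compound 2 in a single place, as follows: 3,4-dichlorophenyl in place of 2,4-dimethoxyphenyl on a saturated ring carbon.

Going by the values given here, no pair of measured compounds differs in exactly one place, so no measured step can be used as a guide for this change. Compound 1 and compound 3, which carry halogen-bearing rings on a different core, give numbers that sit at or below that of compound 2 in this assay, so a drop is the more likely direction. The estimated step from compound 2 to compound 4 is a number 14.5 percentage points lower from compound 2 to compound 4 (beyond the scatter), expected to be modest and possibly not beyond the scatter. Compound 4 is therefore expected to give about 55% in this assay, within a range from 30% to 78%.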

Compound 4, a percentage reported as inhibition, at one concentration (the size of the read-out at that concentration, not a potency): 28.1%
Compound 4: middle estimate off by 26.9 percentage points, on the high side; measured number below the stated range.
By their numbers in this assay, from the lowest: compounds 4 and 1 (each within the scatter of the next); then compounds 3 and 2 (each within the scatter of the next).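

In this assay, a number 41.4 percentage points lower from compound 2 to compound 4 (beyond the scatter). Going by these compounds alone, this is the first change that can be read in a single place, and it shows that the group on the saturated ring carbon can strongly alter the effect at the one concentration tested, even with the rest of the molecule unchanged, so the shared core alone does not fix the result. The change replaces a ring with 2 hydrogen-bond acceptors by one with 0 and brings in two chlorine atoms, but nothing measured here explains why the number falls.

This single step alters both the kind of substituent and where the substituents sit on the aromatic ring, so it cannot separate the loss of the methoxy groups from the arrival of the chlorines, or either of these from the change in their placement. It also leaves open how other groups on the same carbon would behave, such as an unsubstituted phenyl ring, or a phenyl ring carrying an amine or a carboxylic acid.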